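Adding a Second Chloro to Compound 2

A few compounds are considered here, and "the series" means these few. Any claim that something is new, unique, unknown or untested is made for them only; others in the source may bear on it.

Compound 1 `OC[C@H]1O[C@@H](n2cnc3c(NCc4ccccc4Cl)ncnc32)[C@H](O)[C@@H]1O` and compound 2 `OC[C@H]1O[C@@H](n2cnc3c(NCc4ccc(Cl)cc4)ncnc32)[C@H](O)[C@@H]1O` share one core and differ in a single place. In a functional assay on B16 cells (Mus musculus) for antiproliferative activity, with a stated time of 72 h (a lower number here means a stronger inhibitor, a higher number a weaker inhibitor), compound 1 gives only the assay limit > 166000 nM. In this assay compound 2 likewise gives only the limit > 166000 nM. Both sit at the limit of > 166000 nM in this assay, at which 2 of the 2 values shown sit, so the step that the two limits leave unreadable from compound 1 to compound 2 shows no readable size. Compound 3 `OC[C@H]1O[C@@H](n2cnc3c(NCc4ccc(Cl)c(Cl)c4)ncnc32)[C@H](O)[C@@H]1O` carries one further change: chloro in place of hydrogen on an aromatic carbon. With both measured values at the limit, no direction can be drawn, and compound 3 is expected to stay near that limit, a step of a number no higher from compound 2 to compound 3 (the limit leaves the size open). Compound 3 is estimated at 166000 nM, between 40000 nM and 600000 nM.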

Compound 3, half-maximal inhibitory concentration: > 166000 nM
Compound 3 was reported as a limit; the forecaster's own chance of this, stated with the estimate: 80%; the middle value sits exactly at the limit.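

No step can be read in this assay among compound 1, compound 2 and compound 3, because each gives only a limit: the limit of > 166000 nM in this assay, at which 3 of the 3 values shown sit. On these data alone, how strong these compounds really are, and whether moving or adding a chloro changes that, stays open.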